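The compounds below may be only part of what the source reports. "The series", "measured", "known", "first", "only" and "open" are said of these compounds alone.

Going by the values given here, compound 3 `O=C(CSc1nnc(-c2ccncc2)o1)N/N=C/c1ccccc1O` holds the lowest number of the three so far in a functional assay on HepG2 cells (Homo sapiens) for cytotoxicity, read by MTT assay, with a stated time of 48 h (a higher number here means a weaker inhibitor, a lower number a stronger inhibitor), where compound 3 gives 3510 nM. In this assay compound 1 `O=C(CSc1nnc(-c2ccncc2)o1)N/N=C/c1ccc(F)cc1` gives 12300 nM and compound 2 `Cc1ccc(/C=N/NC(=O)CSc2nnc(-c3ccncc3)o2)cc1` gives 10000 nM. The step of a 1.2-fold lower number from compound 1 to compound 2 (0.09 log units; within the scatter) leaves those two level; the steps of a 3.5-fold lower number from compound 1 to compound 3 (0.54 log units; beyond the scatter) and a 2.8-fold lower number from compound 2 to compound 3 (0.45 log units; beyond the scatter) set compound 3 apart from both, beyond the scatter.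

Compound 4 `O=C(CSc1nnc(-c2ccncc2)o1)N/N=C/c1ccc(O)c(O)c1` carries the change (3,4-dihydroxyphenyl in place of 2-hydroxyphenyl on a carbon with a double bond to nitrogen). The measured steps that bear on it are the aryl swaps at that same carbon, a 3.5-fold lower number from compound 1 to compound 3 (0.54 log units; beyond the scatter) and a 2.8-fold lower number from compound 2 to compound 3 (0.45 log units; beyond the scatter); each was modest, and each ran toward a lower number when the entering aryl group carried a hydroxy group. Among the compounds with values here, no measured step shifts a hydroxy group around the ring or adds a second one, so the present change has no direct precedent, and the size and direction of its effect in this assay cannot be read from any pair on hand.

For compound 4 a step of a 1.2-fold lower number from compound 3 to compound 4 (0.07 log units; within the scatter) is expected, essentially within the scatter. Compound 4 is estimated at 3000 nM in this assay, with a range from 1000 nM to 10000 nM.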

Compound 4, half-maximal inhibitory concentration: 760 nM
Compound 4: the middle estimate sits 3.9-fold (0.60 log units) above what was measured, outside the stated range (below it).
By their numbers in this assay, from the lowest: compound 4; then compound 3; then compounds 2 and 1 (each within the scatter of the next).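

In this assay, going by these compounds alone, the carbon with a double bond to nitrogen now shows much more range than the earlier modest steps suggested: 3,4-dihydroxyphenyl in place of 2-hydroxyphenyl gives a 4.6-fold lower number from compound 3 to compound 4 (0.66 log units; beyond the scatter), and the same group in place of the two aryl groups without a hydroxy group gives a 13-fold lower number from compound 2 to compound 4 (1.12 log units; beyond the scatter) and a 16-fold lower number from compound 1 to compound 4 (1.21 log units; beyond the scatter), the first large steps at this position. Across these four compounds the number falls as the aryl group goes from no hydroxy group to one to two, with no compound against that order, although compound 3 and compound 4 differ in both the number and the placement of their hydroxy groups, so the two effects cannot be separated. Nothing on hand gives a reason for the size of these steps.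

Still open, as far as these compounds go, is whether both hydroxy groups of 3,4-dihydroxyphenyl are needed for the lower number, or whether a single hydroxy group placed differently would do as well. Also open, from the compounds shown here alone, is how a methoxy group or an amine in place of those hydroxy groups would read in this assay.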